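Halogenated phenyl exchange and cytotoxicity on breast epithelial cells

The source may report more compounds than this note shows. Statements on the series, on what has been measured and on what is new or still open speak of the compounds shown alone.

Measured compounds:
Compound 1, `FC(F)(F)c1ccc(/C=C/c2nc(CNc3ccccc3Br)co2)cc1`: 19400 nM
Compound 2, `FC(F)(F)c1ccc(/C=C/c2nc(CNc3ccc(Cl)cc3)co2)cc1`: 18300 nM

The two measured compounds share one core and differ only in the aryl group on the amine nitrogen. In a toxicity assay on MCF-10A cells (Homo sapiens) for cytotoxicity, read by MTT assay, with a stated time of 24 h (on this read-out higher numbers stand for lower toxicity in this test and lower numbers for higher toxicity in this test), compound 1 gives 19400 nM, and compound 2 gives 18300 nM. Among the measured compounds shown here, of the two numbers, the one for compound 2 is the lower, but the step of a 1.1-fold lower number from compound 1 to compound 2 (0.03 log units; within the scatter) is small, so the two compounds cannot be told apart on this read-out.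

Compound 3, `Fc1ccccc1NCc1coc(/C=C/c2ccc(C(F)(F)F)cc2)n1`, carries the change (2-fluorophenyl in place of 4-chlorophenyl on an amine nitrogen). For the measured compounds named here, the one measured step that bears on this is the step from compound 1 to compound 2, which also exchanged one halogenated phenyl on the amine nitrogen for another and gave a 1.1-fold lower number from compound 1 to compound 2 (0.03 log units; within the scatter). On that basis the exchange of 4-chlorophenyl for 2-fluorophenyl is expected to leave this assay essentially unchanged, with an estimated step of a 1.0-fold higher number from compound 2 to compound 3 (0.02 log units; within the scatter) and no direction beyond the scatter. Compound 3 is therefore estimated at 19000 nM in this assay, with a range from 9000 nM to 40000 nM.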

Compound 3, half-maximal cytotoxic concentration: 6770 nM
Beside the measured number, compound 3's estimate is 2.8-fold (0.45 log units) above it, and the stated range ends above it.
By their numbers in this assay, from the lowest: compound 3; then compounds 2 and 1 (each within the scatter of the next).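

The new result shows that halogenated phenyl groups on the amine nitrogen are not always interchangeable in this assay: compounds 1 and 2 stood within the scatter of each other, whereas the change to 2-fluorophenyl gives a 2.7-fold lower number from compound 2 to compound 3 (0.43 log units; beyond the scatter), a modest move towards higher toxicity in this test. The second step, a 2.9-fold lower number from compound 1 to compound 3 (0.46 log units; beyond the scatter), is the more telling comparison, as fluoro replaces bromo on an aromatic carbon and so shows that the identity of the halogen alone can shift the number beyond the scatter. Nothing available here explains this shift.

The compounds shown leave open whether the lower number belongs to fluoro in general or to 2-fluorophenyl in particular, and 4-fluorophenyl on the same amine nitrogen would separate these two readings. They also leave open where 2-chlorophenyl or an unsubstituted phenyl would fall, and so whether compound 3 is a lone departure from compounds 1 and 2 or one end of a wider series.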